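The compounds below may be only part of what the source reports. "The series", "measured", "known", "first", "only" and "open" are said of these compounds alone.

Notes on the series. Among the compounds with values here, in an assay on lysate for inhibition of 6-phosphofructo-2-kinase/fructose-2,6-bisphosphatase 3 (Homo sapiens), with stated times of 0.5 min and 45 min (on this read-out higher numbers stand for weaker inhibition and lower numbers for stronger inhibition), compound 1 `CN1CCC(CNS(=O)(=O)c2ccccc2Nc2cc(-c3ccc4ccn(C)c4c3)c3nccnc3c2)C1` gives 4640 nM and compound 2 `CN(C)S(=O)(=O)c1ccccc1Nc1cc(-c2ccc3ccn(C)c3c2)c2nccnc2c1` gives 7670 nM; the single step between them, a 1.7-fold higher number from compound 1 to compound 2 (0.22 log units; within the scatter), concerns a group on the sulfonyl sulfur only. Compound 3 `Cn1ccc2ccc(-c3cc(Nc4cnccc4C(=O)NCc4cncnc4)cc4nccnc34)cc21` gives 49500 nM in this assay, the highest number of the three: compound 2 stands nearest and compound 1 furthest, both gaps beyond the scatter. Compound 4 `Cn1ccc2ccc(-c3cc(Nc4cnccc4C(=O)NC4CCNC(=O)C4)cc4nccnc34)cc21` differs from compound 3 in one place: 2-oxopiperidin-4-yl in place of (pyrimidin-5-yl)methyl on an amide-type nitrogen. Within the data shown here, no measured step touches this amide-type nitrogen; the only step available, from compound 1 to compound 2, sits on another part of the molecule and stayed within the scatter, so it gives no direction for the present exchange. In this assay no step beyond the scatter is therefore expected for compound 4, with a wide band to either side, a 1.0-fold higher number from compound 3 to compound 4 (0.00 log units; within the scatter). Compound 4 is accordingly estimated at 50000 nM in this assay, between 15000 nM and 160000 nM, with a real chance that only a limit is reported.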

Compound 4, half-maximal inhibitory concentration: 56500 nM
Compound 4: the middle estimate sits 1.1-fold (0.05 log units) below what was measured; measured number inside the range.
By their numbers in this assay, from the lowest: compounds 1 and 2 (each within the scatter of the next); then compounds 3 and 4 (each within the scatter of the next).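

Within the data shown here, on the amide-type nitrogen, 2-oxopiperidin-4-yl in place of (pyrimidin-5-yl)methyl gives in this assay a 1.1-fold higher number from compound 3 to compound 4 (0.06 log units; within the scatter), the only measured step at this position. The exchange replaces a six-membered aromatic ring with 2 hetero atoms by a six-membered non-aromatic ring with 1 hetero atom and adds a hydrogen-bond donor at an equal heavy-atom count, yet the read-out does not separate the two groups. The data offer no explanation for this result.

Still open, on these data alone, is whether a group of another kind on this nitrogen, such as a 2-aminoethyl chain or one ending in a carboxylic acid, would give a step beyond the scatter. Compounds 3 and 4 differ from compounds 1 and 2 in more than one place, so the part of the molecule behind that gap remains unresolved.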